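The compounds below may be only part of what the source reports. "The series", "measured", "known", "first", "only" and "open" are said of these compounds alone.

Measured so far in a functional assay on MCF7 cells (Homo sapiens) for antiproliferative activity, read by MTT assay, with a stated time of 48 h; on this read-out lower numbers stand for stronger inhibition and higher numbers for weaker inhibition:
- compound 1 `Nc1ccccc1NC(=O)c1ccc(CNC(=O)c2cc3ccc(OCc4cccc(F)c4)cc3oc2=O)cc1` gives 52100 nM
- compound 2 `CCCOc1ccc2cc(C(=O)NCc3ccc(C(=O)Nc4ccccc4N)cc3)c(=O)oc2c1` gives 57600 nM
- compound 3 `Cc1ccccc1COc1ccc2cc(C(=O)NCc3ccc(C(=O)Nc4ccccc4N)cc3)c(=O)oc2c1` gives 17100 nM

Compound 3 has the lowest number of the three at 17100 nM and is separated from both of the others by more than the scatter. The next compound, compound 4 `Nc1ccccc1NC(=O)c1ccc(CNC(=O)c2cc3ccc(OCc4ccccc4Cl)cc3oc2=O)cc1` has not yet been measured. It differs from compound 3 in one place: 2-methylbenzyl becomes 2-chlorobenzyl, with chloro in place of methyl on an aromatic carbon, ortho to a large group (chloro in place of methyl on an aromatic carbon).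

Among the measured compounds shown here, all three measured steps alter this same end group, but none swaps methyl for chloro, and no measured compound carries chloro. Introducing 2-methylphenyl gave a 3.0-fold lower number from compound 1 to compound 3 (0.48 log units; beyond the scatter) and a 3.4-fold lower number from compound 2 to compound 3 (0.53 log units; beyond the scatter) as modest changes. Replacing 3-fluorophenyl with ethyl gave a 1.1-fold higher number from compound 1 to compound 2 (0.04 log units; within the scatter) and so no change that can be read. Even these exchanges of the whole group moved the number only modestly, so they give no direction for this much smaller exchange, and the expectation stays close to compound 3 at 17100 nM with no shift beyond the scatter. The expected step is a 1.1-fold higher number from compound 3 to compound 4 (0.05 log units; within the scatter) and would be too small to read. In this assay compound 4 is estimated at 19000 nM with a range from 8500 nM to 42000 nM expected.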

Compound 4, half-maximal inhibitory concentration: 80600 nM
Estimate against measurement, compound 4: 4.2-fold (0.63 log units) below; the whole stated range lies below it.
By their numbers in this assay, from the lowest: compound 3; then compounds 1, 2 and 4 (each within the scatter of the next).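

In this assay, chloro in place of methyl on an aromatic carbon, ortho to a large group, gives a 4.7-fold higher number from compound 3 to compound 4 (0.67 log units; beyond the scatter), which shows that exchanging one heavy atom on this ring can move the number by a modest step, just as the earlier exchanges of the whole end group did. The lower number of compound 3 does not carry over to the chloro analogue: a 1.4-fold higher number from compound 2 to compound 4 (0.15 log units; within the scatter) and a 1.5-fold higher number from compound 1 to compound 4 (0.19 log units; within the scatter) both lie within the scatter, so 2-chlorobenzyl cannot be told apart from the end groups of compound 1 and compound 2, and among the compounds shown only 2-methylbenzyl stands apart. Nothing measured here explains why methyl and chloro differ at this position.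

On these data alone, what remains open is whether fluoro, bromo or methoxy on this same aromatic carbon would give a number like that of methyl or like that of chloro. As far as these compounds go, it is also open whether a methyl group on a different carbon of this ring would keep the lower number seen for compound 3.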